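The source may hold more compounds than are shown below. What is called first, only, known or untested is meant among the compounds shown, and "the series" means these compounds.

Three compounds of this series carry a measured number in an assay for inhibition of serine/threonine-protein kinase PLK2 (Homo sapiens), read by FRET and Z'-LYTE, with a stated time of 1 h; on this read-out lower numbers stand for stronger inhibition and higher numbers for weaker inhibition. Compound 1 `CCC1C(=O)N(C)c2cnc(-n3ccc4cc(C(=O)NC)ccc43)nc2N1c1ccn(C)n1` gives 218 nM, the highest of the three. Compound 3 `CCC1C(=O)N(C)c2cnc(Nc3ccc(S(=O)(=O)NCCCO)cc3)nc2N1c1ccn(C)n1` gives 192 nM, which sits within the scatter of compound 1. Compound 2 `CC[C@@H]1C(=O)N(C)c2cnc(Nc3ccc(S(N)(=O)=O)cc3)nc2N1C1CCCC1` gives 10.2 nM, a number beyond the scatter below compound 1. Among the compounds with values here, no two of these differ in one place only, so no single structural step is isolated among them. Compound 4 `CCCCNC(=O)c1ccc2c(ccn2-c2ncc3c(n2)N(c2ccn(C)n2)C(CC)C(=O)N3C)c1` is not yet measured; against compound 1 the difference is propyl in place of hydrogen on a saturated chain carbon bound to an amide-type nitrogen, which amounts to methylcarbamoyl becoming butylcarbamoyl. Within the data shown here, no measured pair shows what this propyl does. The expected step from compound 1 is small, not beyond the scatter in either direction: a 1.1-fold lower number from compound 1 to compound 4 (0.04 log units; within the scatter). Compound 4 is estimated at 200 nM, between 80 nM and 500 nM.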

Compound 4, half-maximal inhibitory concentration: 159 nM
Estimate against measurement, compound 4: 1.3-fold (0.10 log units) above; the range from low to high includes it.
By their numbers in this assay, from the lowest: compound 2; then compounds 4, 3 and 1 (each within the scatter of the next).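

In this assay, within the data shown here, the change from methylcarbamoyl to butylcarbamoyl gives the first single-place step: a 1.4-fold lower number from compound 1 to compound 4 (0.14 log units; within the scatter), so the added propyl on a saturated chain carbon bound to an amide-type nitrogen is tolerated. No information bears on the cause of this result.

On these data alone, whether a longer chain, or a butyl chain ending in an amine or a carboxylic acid, would stay within the scatter remains open. Among these compounds, compound 2 differs from the others in more than one place, so no step to it can be read.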